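The compounds below may be only part of what the source reports. "The series", "measured", "known", "first", "only" and "open" are said of these compounds alone.

Measured in an ADME assay on Caco-2 cells (Homo sapiens) for permeability, in the apical to basolateral direction; a lower number here means that the compound crosses the layer more slowly, a higher number that the compound crosses the layer faster:

Compound 1, `Cn1cncc1CN1CC(N(CC2CCN(C(=O)C3CCCC3)CC2)S(=O)(=O)c2ccccn2)Cc2cc(C#N)ccc21`: 0.5 10^-6 cm/s
Compound 2, `CC(C)C(=O)N1CCC(CN(C2Cc3cc(C#N)ccc3N(Cc3cncn3C)C2)S(=O)(=O)c2ccccn2)CC1`: 0.5 10^-6 cm/s

Among the compounds with values here, compound 2 stands level with compound 1: the only measured step, no change at the digits printed from compound 1 to compound 2 (within the scatter), left the reading where it was. That step swapped one alkyl group for another on the same carbonyl carbon, with the amide itself kept in place.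

Compound 3, `Cn1cncc1CN1CC(N(CC2CCN(S(=O)(=O)c3ccccc3)CC2)S(=O)(=O)c2ccccn2)Cc2cc(C#N)ccc21`, has not yet been measured in this assay. It differs from compound 2 in one place: phenylsulfonyl in place of isopropylcarbonyl on an amine nitrogen in a ring. Here the carbonyl group leaves altogether and a phenylsulfonyl enters on the ring nitrogen, so this is a change of a different kind from the one already measured; the step of no change at the digits printed from compound 1 to compound 2 (within the scatter) bears on it only loosely, showing that the group on that ring nitrogen could be varied without moving the reading. With nothing closer to go on, the expected step of no change at the digits printed from compound 2 to compound 3 (within the scatter) is none beyond the scatter. The estimate for compound 3 is therefore 0.5 10^-6 cm/s, with a range from 0.2 10^-6 cm/s to 1.5 10^-6 cm/s.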

Compound 3, apparent permeability: 0.1 10^-6 cm/s
Compound 3: middle estimate off by 5.0-fold (0.70 log units), on the high side; the measured number lies below the stated range.
By their numbers in this assay, from the lowest: compound 3; then compounds 1 and 2 (each within the scatter of the next).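

In this assay, putting phenylsulfonyl on the ring nitrogen in place of isopropylcarbonyl gave a 5.0-fold lower number from compound 2 to compound 3 (0.70 log units; beyond the scatter), and putting it there in place of cyclopentylcarbonyl gave a 5.0-fold lower number from compound 1 to compound 3 (0.70 log units; beyond the scatter). The earlier pair suggested that this ring nitrogen tolerated variation, with no change at the digits printed from compound 1 to compound 2 (within the scatter), but that pair only exchanged one alkyl group for another on a retained carbonyl, whereas the new result shows that the reading at this position can move when the carbonyl itself is replaced. The new group differs from the old ones in two ways at once, with a sulfonyl in place of the carbonyl and a carbon-only aromatic ring added, and no available measurement explains the lower number.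

These compounds leave open which of the two differences goes with the lower reading: a benzoyl group would keep the carbonyl and add the aromatic ring, whereas a methylsulfonyl group would keep the sulfonyl without that ring. From the compounds shown here alone, whether either group would stay level with compound 1 or fall towards compound 3 remains unknown.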